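Aryl swap on the ring nitrogen: compound 2 to compound 3

The source may hold more compounds than are shown below. What is called first, only, known or untested is meant among the compounds shown, and "the series" means these compounds.

Compound 2 `CCOC(=O)c1c(-c2cc3ccccc3oc2=O)nn(-c2cccc(C)c2)c1C(=O)OCC` gives 52000 nM in a functional assay on A549 cells (Homo sapiens) for cytotoxicity, read by MTT assay, with a stated time of 48 h; on this read-out lower numbers stand for stronger inhibition and higher numbers for weaker inhibition. Compound 1 `CCOC(=O)c1c(-c2c(Cl)c3ccccc3oc2=O)nn(-c2cccc(C)c2)c1C(=O)OCC` gives 36000 nM in this assay. Compound 2 therefore stands at the highest of the two numbers recorded so far, its nearest neighbour being compound 1; the step of a 1.4-fold higher number from compound 1 to compound 2 (0.16 log units; within the scatter) is the only one measured, and it concerns hydrogen in place of chloro on an aromatic carbon of the bicyclic part.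

Compound 3 `CCOC(=O)c1c(-c2cc3ccccc3oc2=O)nn(-c2ccc(Cl)cc2)c1C(=O)OCC` differs from compound 2 by 4-chlorophenyl in place of 3-methylphenyl on an aromatic nitrogen. Going by the values given here, no measured step touches the group on the aromatic nitrogen; the single step on record, a 1.4-fold higher number from compound 1 to compound 2 (0.16 log units; within the scatter), lies elsewhere in the molecule and was itself within the scatter. There is thus no measured basis for expecting compound 3 to move in either direction, and the working expectation is a step of no size beyond the scatter, a 1.0-fold lower number from compound 2 to compound 3 (0.02 log units; within the scatter).

Compound 3 is accordingly estimated at 50000 nM in this assay, with a range from 15000 nM to 160000 nM.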

Compound 3, half-maximal inhibitory concentration: 35000 nM
For compound 3 the middle estimate is 1.4-fold (0.15 log units) above the measured one; the measured number falls inside the stated range.
By their numbers in this assay, from the lowest: compounds 3, 1 and 2 (each within the scatter of the next).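

Going by these compounds alone, the group on the aromatic nitrogen of the five-membered ring can now be read for the first time: in this assay, 4-chlorophenyl in place of 3-methylphenyl gives a 1.5-fold lower number from compound 2 to compound 3 (0.17 log units; within the scatter). This position therefore accepts one substituted phenyl group in place of another without a step beyond the scatter, as did the other place changed so far, where hydrogen in place of chloro gave a 1.4-fold higher number from compound 1 to compound 2 (0.16 log units; within the scatter). No measurement at hand bears on the origin of either step.

The change from 3-methylphenyl to 4-chlorophenyl alters the substituent and its place on the phenyl ring together, so the compounds shown do not separate the two, and all three numbers lie so close that no step yet marks a group on the aromatic nitrogen as mattering in this assay. Still open, on these data alone, is whether an unsubstituted phenyl, a benzyl group or a longer alkyl chain on that nitrogen, or a carboxylic acid in place of an ethoxycarbonyl group, would give a step beyond the scatter.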